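The compounds below may be only part of what the source reports. "The series", "measured", "known", "first", "only" and "open" are said of these compounds alone.

Measured compounds in a functional assay on PLC-PRF-5 cells (Homo sapiens) for inhibition; on this read-out lower numbers stand for stronger inhibition and higher numbers for weaker inhibition:

Compound 1, `CNC(=O)c1cc(Oc2ccc(NS(=O)(=O)c3ccccc3)cc2)ccn1`, gives > 40000 nM, a limit of the assay.
Compound 2, `CNC(=O)c1cc(Oc2ccc(NS(=O)(=O)c3ccc(C(C)(C)C)cc3)cc2)ccn1`, gives > 40000 nM, a limit of the assay.
Compound 3, `O=[N+]([O-])c1cc(C(F)(F)F)ccc1S(=O)(=O)Nc1ccc(Oc2ccnc3ccccc23)cc1`, gives > 40000 nM, a limit of the assay.

Where compound 3 stands: it sits at the limit of this assay, as do both other compounds, so that (the limit of > 40000 nM in this assay, at which 3 of the 3 values shown sit). No number separates compound 3 from compound 1 or compound 2; of these pairs only the limits are known. Going by the values given here, the single one-point step measured, a step that the two limits leave unreadable from compound 1 to compound 2, runs between two limits and gives no readable size.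

Compound 4 is `O=[N+]([O-])c1cc(C(F)(F)F)ccc1S(=O)(=O)Nc1ccc(Oc2ccnc3c([N+](=O)[O-])cccc23)cc1`. It differs from compound 3 in one place: nitro in place of hydrogen on an aromatic carbon. Among the compounds with values here, none of the measured steps concerns a nitro group for hydrogen, and the one measured step gives no size in any case, so no measured step bears on this change.

With every value in the series at the limit, the expected step of a number no higher from compound 3 to compound 4 (the limit leaves the size open) is one that cannot be read from the data at hand. Compound 4 is therefore expected to give 40000 nM in this assay, with a range from 10000 nM to 100000 nM, most likely reported again as a limit rather than as a number.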

Compound 4, half-maximal inhibitory concentration: > 40000 nM
Compound 4 ended at the assay's limit; the forecaster's own chance of this, stated with the estimate: 80%; the middle value sits exactly at the limit.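

In this assay compound 4 gives > 40000 nM, a limit and not a number. Compound 3 also stands at a limit, so no step can be read between compound 3 and compound 4, and the series offers no number for comparison: the limit of > 40000 nM in this assay, at which 4 of the 4 values shown sit.

The compounds shown leave open what size, if any, the change from hydrogen to nitro has, and which structures in this series would give a measurable value in this assay.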